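The source may hold more compounds than are shown below. What is called first, only, known or untested is meant among the compounds shown, and "the series" means these compounds.

Of the compounds shown here, three have numbers so far in a functional assay (aorta) for inhibition, with Rattus norvegicus as the target; on this read-out lower numbers stand for an effect already at smaller amounts and higher numbers for an effect only at larger amounts of compound. Compound 1 `O=C1C(Nc2ccc(Br)cc2)=CC(=O)c2ncccc21` gives 302 nM, compound 2 `O=C1C(Nc2ccc(C(F)(F)F)cc2)=CC(=O)c2ncccc21` gives 607 nM, and compound 3 `O=C1C=C(Nc2ccccc2)C(=O)c2cnccc21` gives 439 nM. The value of compound 3 lies within the usual scatter of both of the others, so these numbers do not rank it against them.

Compound 4 `O=C1C=C(Nc2ccc(F)cc2)C(=O)c2cnccc21` is compound 3 with fluoro in place of hydrogen on an aromatic carbon. For the measured compounds named here, no measured pair shows this exact change, so the evidence is only indirect. The nearest guide is a swap of one group for another on an aromatic carbon, trifluoromethyl in place of bromo, which gave a 2.0-fold higher number from compound 1 to compound 2 (0.30 log units; within the scatter). That is a different exchange on a different core from that of compound 3, and it shows how little is known rather than predicting the new change.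

Going by the values given here, with a 2.0-fold higher number from compound 1 to compound 2 (0.30 log units; within the scatter) as the only measured step, no shift beyond the scatter is expected in this assay, and neither direction is favoured. The estimated step is a 1.1-fold lower number from compound 3 to compound 4 (0.04 log units; within the scatter), which is expected to stay within the scatter. The estimate for compound 4 is 400 nM, with an expected range from 190 nM to 850 nM.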

Compound 4, half-maximal effective concentration: 1230 nM
Compound 4: the middle estimate sits 3.1-fold (0.49 log units) below what was measured; measured number outside the range, above it.
By their numbers in this assay, from the lowest: compounds 1, 3 and 2 (each within the scatter of the next); then compound 4.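

In this assay, adding one fluoro on an aromatic carbon, para to a large group, gives a 2.8-fold higher number from compound 3 to compound 4 (0.45 log units; beyond the scatter), and this is the first step among these compounds that lies beyond the usual scatter. For the compounds shown here, the only earlier step, a 2.0-fold higher number from compound 1 to compound 2 (0.30 log units; within the scatter), stayed within the scatter and swapped one group for another on a different core, so it could not show that this position on the core of compound 3 responds to a change as small as one heavy atom in place of hydrogen. Here the added fluoro goes with a higher number, meaning that a larger amount of compound 4 is needed for the effect, but nothing available explains why the number rises.

Going by these compounds alone, one step with one group cannot show whether the rise is specific to fluoro or would follow any group placed here on this core, and bromo and trifluoromethyl are seen only on the core of compound 1. A methoxy group, an amine or a carboxylic acid at this same position on the core of compound 3 would help to answer that, as would fluoro on the core of compound 1.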